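Acylhydrazone series: removing the chloro from the aryl ring

This account rests on a few compounds, and the source may have more. Where it says the series, first, only, none or still open, it means among the compounds named here.

Two compounds of this series have been run in a functional assay on NCI/ADR-RES cells (Homo sapiens) for antiproliferative activity, read by sulforhodamine B assay, with a stated time of 48 h; on this read-out lower numbers stand for stronger inhibition of growth and higher numbers for weaker inhibition of growth. Compound 1 `COc1ccc(OC)c(/C=C/c2nnc(Nc3ccc(Cl)cc3)o2)c1` gives 98100 nM. Compound 2 `COc1ccc(OC)c(/C=C/C(=O)N/N=C/c2ccc(Cl)cc2)c1` gives 233 nM. Compound 2 thus holds the lowest number of the two, and its gap to compound 1 lies well beyond the scatter of this assay.

The next compound, compound 3 `COc1ccc(OC)c(/C=C/C(=O)N/N=C/c2ccccc2)c1`, is compound 2 with hydrogen in place of chloro on an aromatic carbon; the same difference, cut one bond further out, reads 4-chlorophenyl to phenyl. Among the measured compounds shown here, no step between two measured compounds covers this change, so nothing measured here tells how large its effect is. For compound 3 a modest rise in the number is expected, a 2.1-fold higher number from compound 2 to compound 3 (0.33 log units; beyond the scatter), of a size that may still fall within the scatter. Compound 3 is estimated at 500 nM, with a range from 150 nM to 2000 nM.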

Compound 3, concentration for total growth inhibition: 4290 nM
The estimate for compound 3 lay 8.6-fold (0.93 log units) below the measured number; the measured number lies above the stated range.
By their numbers in this assay, from the lowest: compound 2; then compound 3; then compound 1.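

In this assay, the chloro on the aromatic carbon, para to a large group, proves to matter strongly in this pair: an 18-fold higher number from compound 2 to compound 3 (1.27 log units; beyond the scatter), a large step for the loss of 1 heavy atom with no hydrogen-bond donor or acceptor involved. Among the compounds shown here, compound 1 differs from compound 2 in more than one place, so only this step puts a size on the change from 4-chlorophenyl to phenyl. No measured property is available to explain the size of this step.

On these data alone, whether this effect is specific to chlorine remains open; fluoro, bromo, methoxy or an amine on the same carbon would separate chlorine from other groups. Also open, as far as these compounds go, is whether the same change has a similar effect on a different core.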